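The source may report more compounds than this note shows. Statements on the series, on what has been measured and on what is new or still open speak of the compounds shown alone.

Measured so far in a functional assay on A-375 cells (Homo sapiens) for antiproliferative activity, read by MTT assay, with a stated time of 24 h, tested at 1.23 ug/mL; on this read-out lower numbers stand for a weaker effect and higher numbers for a stronger effect at the one concentration tested:
- compound 1, `Cc1ccc2nc(C(=O)Nc3c(F)cc(-c4cccc(F)c4)cc3F)c(C)c(O)c2c1`: 3.04%
- compound 2, `Cc1c(C(=O)Nc2c(F)cc(-c3cccc(F)c3)cc2F)nc2ccc(OC(F)(F)F)cc2c1O`: 1.57%

Both numbers stand for a weak effect at the single concentration tested. Compound 1 has the highest of the two numbers; its nearest neighbour is compound 2, with a number 1.5 percentage points lower from compound 1 to compound 2 (within the scatter), a step that does not separate the two compounds. Among the compounds with values here, that step comes from trifluoromethoxy in place of methyl on an aromatic carbon and is the only measured step.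

Compound 3, `Cc1ccc2nc(C(=O)Nc3c(F)cc(-c4cccc(F)c4)cc3F)c(C)c(C(=O)O)c2c1`, is not yet measured. It differs from compound 1 by carboxy in place of hydroxy on an aromatic carbon. Within the data shown here, no measured step concerns this group or this kind of exchange; the one step that exists, a number 1.5 percentage points lower from compound 1 to compound 2 (within the scatter), involves a different group and was within the scatter. Nothing in the numbers therefore supports a move in either direction, and the expected step is a number 0 percentage points lower from compound 1 to compound 3 (within the scatter), none beyond the scatter. Compound 3 is accordingly estimated at 3% in this assay, with an expected range from -7% to 13% that reflects the scatter alone.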

Compound 3, a percentage reported as inhibition, at one concentration (the size of the read-out at that concentration, not a potency): 3.65%
Estimate against measurement, compound 3: 0.7 percentage points below; measured number inside the range.
By their numbers in this assay, from the lowest: compounds 2, 1 and 3 (each within the scatter of the next).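

In this assay, carboxy in place of hydroxy on the aromatic carbon opposite the ring nitrogen and ortho to a methyl group gives a number 0.6 percentage points higher from compound 1 to compound 3 (within the scatter), so this exchange does not separate the two compounds. Within the data shown here, this is the only step at this position, as compound 1 and compound 2 both carry hydroxy there; it shows that going from 1 heavy atom to 3 heavy atoms at this place leaves the reading within the scatter, with the hydrogen-bond donor and acceptor counts unchanged. No evidence on the cause of this result is available.

Still open, going by these compounds, is whether another group at this position, such as an amine, a methoxy group or a longer chain, would give a step beyond the scatter in this assay. Also open are whether carboxy at this place would behave the same alongside the trifluoromethoxy group of compound 2, and whether any of these compounds would separate at a concentration other than the single one tested.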